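From aryl to oxanyl on the sulfonyl sulfur

A few compounds are considered here, and "the series" means these few. Any claim that something is new, unique, unknown or untested is made for them only; others in the source may bear on it.

Among the compounds with values here, only two compounds have numbers so far. In a functional assay on A2780 cells (Homo sapiens) for cytotoxicity, read by sulforhodamine B assay, with a stated time of 72 h (on this read-out higher numbers stand for weaker inhibition and lower numbers for stronger inhibition), compound 1 `O=C(NCc1ccc(S(=O)(=O)c2ccccc2)cc1)c1cc2cnccc2[nH]1` gives 18 nM and compound 2 `O=C(NCc1ccc(S(=O)(=O)c2cccc(C(F)(F)F)c2)cc1)N1Cc2ccncc2C1` gives 2.7 nM as the lower of the two numbers, with a gap beyond the usual scatter. Compound 3 `O=C(NCc1ccc(S(=O)(=O)C2CCCOC2)cc1)N1Cc2ccncc2C1` differs from compound 2 in one group: oxan-3-yl in place of 3-(trifluoromethyl)phenyl on a sulfonyl sulfur. Within the data shown here, no measured pair shows a change of this kind, so the expectation rests on the structural change alone and remains rough. The aromatic group that leaves is larger than the ring that enters, and some loss is expected. The estimated change in this assay is a step to a higher number, expected as a 4.4-fold higher number from compound 2 to compound 3 (0.65 log units; beyond the scatter) and probably beyond the scatter. For compound 3 the estimated value is 12 nM with an expected range from 3 nM to 50 nM once measured.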

Compound 3, half-maximal inhibitory concentration: 32 nM
For compound 3 the middle estimate is 2.7-fold (0.43 log units) below the measured one; low and high end bracket the measured number.
By their numbers in this assay, from the lowest: compound 2; then compounds 1 and 3 (each within the scatter of the next).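

In this assay, within the data shown here, putting oxan-3-yl in place of 3-(trifluoromethyl)phenyl on the sulfonyl sulfur gives a 12-fold higher number from compound 2 to compound 3 (1.07 log units; beyond the scatter), the first step that can be read between compounds differing in one place. It shows that this position is sensitive to the group it carries, although compound 3 still gives 32 nM. No measurement shown accounts for the size of this step.

The change removes the aromatic ring and the trifluoromethyl group and brings in a ring oxygen all at once, so the compounds shown cannot separate these contributions. From the compounds shown here alone, whether a cyclohexyl group on the same sulfur, which has a non-aromatic ring without the oxygen, would fall nearer compound 2 or compound 3 remains open.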